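The source may hold more compounds than are shown below. What is called first, only, known or untested is meant among the compounds shown, and "the series" means these compounds.

Measured compounds:
compound 1 `Cc1cc(F)cc(Nc2cc(NC(=O)Nc3c(Cl)cccc3Cl)ncn2)c1`: 78.1%
compound 2 `COc1ccc(Br)cc1Nc1cc(NC(=O)Nc2c(Cl)cccc2Cl)ncn1`: 33%

Among the measured compounds shown here, in a functional assay on NCI-H226 cells (Homo sapiens) for inhibition, read by MTT assay, with a stated time of 48 h, tested at 10 uM (on this read-out lower numbers stand for less inhibition and higher numbers for more inhibition at the one concentration tested (going by the name of the read-out)), compound 1 gives 78.1% and compound 2 gives 33%; compound 2 thus stands lowest of the two numbers, with compound 1 as its only and nearest neighbour. For the measured compounds named here, the single step measured so far, a number 45.1 percentage points lower from compound 1 to compound 2 (beyond the scatter), shows that the aryl group on the nitrogen on the aromatic ring can move the read-out by a large amount. Compound 3 `COc1ccc(Nc2cc(NC(=O)Nc3c(Cl)cccc3Cl)ncn2)cc1C` is not yet measured; it differs from compound 2 by 4-methoxy-3-methylphenyl in place of 5-bromo-2-methoxyphenyl on a nitrogen on an aromatic ring. Going by the values given here, no measured step covers this exact exchange. Compound 3 shares a methyl with compound 1 and a methoxy with compound 2, so the recorded step only shows that such exchanges can be large, not where this one lands. An upward step is expected, a number 22 percentage points higher from compound 2 to compound 3 (beyond the scatter), with wide uncertainty. The estimate for compound 3 in this assay is 55%, with a range from 25% to 85%.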

Compound 3, a percentage reported as inhibition, at one concentration (the size of the read-out at that concentration, not a potency): 50%
Compound 3: middle estimate off by 5 percentage points, on the high side; the measured number falls inside the stated range.
By their numbers in this assay, from the lowest: compound 2; then compound 3; then compound 1.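

In this assay, 4-methoxy-3-methylphenyl in place of 5-bromo-2-methoxyphenyl on a nitrogen on an aromatic ring gives a number 17 percentage points higher from compound 2 to compound 3 (beyond the scatter), so an aryl group carrying a methoxy at this position is not tied to the lowest number. The same group in place of 3-fluoro-5-methylphenyl gives a number 28.1 percentage points lower from compound 1 to compound 3 (beyond the scatter), which places compound 3 between the other two and shows graded values at this position rather than a split into two levels. No measurement here accounts for this order among the three aryl groups.

Each exchange alters more than one substituent at once, so the separate contributions of the bromine, fluorine, methyl and methoxy remain unresolved. Also open, on these data alone, is how an amine or a carboxylic acid on this aryl ring would compare with compound 1.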